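The compounds below may be only part of what the source reports. "The series", "measured", "known", "first", "only" and "open" are said of these compounds alone.

Compound 1 `O=C(COc1ccccc1)Nc1nnc(-c2ccc(O)c(O)c2)s1` gives 30900 nM
Compound 2 `O=C(Nc1nnc(-c2ccc(O)c(O)c2)s1)c1ccc(Cl)cc1` gives 30600 nM

Among the measured compounds shown here, in an ADME assay on MRC5 cells (Homo sapiens) for cytotoxicity, read by MTT assay, with a stated time of 72 h (a lower number here means a stronger inhibitor, a higher number a weaker inhibitor), compound 2 at 30600 nM stands level with compound 1, the only other number so far, and the gap between them lies within the scatter. Compound 3 `O=C(Nc1nnc(-c2ccc(O)c(O)c2)s1)c1ccccc1` keeps the core of compound 2 but has hydrogen in place of chloro on an aromatic carbon, para to a large group (hydrogen in place of chloro on an aromatic carbon), which turns 4-chlorophenyl into phenyl. For the measured compounds named here, no measured step removes this chloro directly. The nearest evidence is a 1.0-fold lower number from compound 1 to compound 2 (0.00 log units; within the scatter) with 4-chlorophenyl in place of phenoxymethyl on a carbonyl carbon, and that larger swap stayed within the scatter. A shift beyond the scatter is therefore not expected, in either direction. The estimated step is a 1.0-fold higher number from compound 2 to compound 3 (0.02 log units; within the scatter) for this small edit. For compound 3 the expected value is 32000 nM with 15000 nM to 68000 nM as the expected range.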

Compound 3, half-maximal inhibitory concentration: 27400 nM
Beside the measured number, compound 3's estimate is 1.2-fold (0.07 log units) above it, and the stated range covers the measured number.
By their numbers in this assay, from the lowest: compounds 3, 2 and 1 (each within the scatter of the next).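

Among the compounds shown here, this is the first direct reading of the chloro itself. In this assay, replacing it with hydrogen on the aromatic carbon, para to a large group, gives a 1.1-fold lower number from compound 2 to compound 3 (0.05 log units; within the scatter) and so shows no effect of the chloro that can be told apart from the scatter. The plain phenyl on the carbonyl carbon also reads level with phenoxymethyl, with a 1.1-fold lower number from compound 1 to compound 3 (0.05 log units; within the scatter) and so all three groups tried there give matching numbers, but nothing available explains this.

On these data alone, whether an amine or a carboxylic acid on that ring, or a longer chain on the carbonyl carbon, would shift the number beyond the scatter remains open. As far as these compounds go, what the shared core contributes to the cytotoxicity also remains open, as it stays the same in all three compounds.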